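From compound 3 to compound 4: a pyrazolyl exchange

This account rests on a few compounds, and the source may have more. Where it says the series, first, only, none or still open, it means among the compounds named here.

Measured so far in a functional assay on HL-60 cells (Homo sapiens) for inhibition (a lower number here means a stronger inhibitor, a higher number a weaker inhibitor), and still open for compound 4
compound 1 `OC[C@H]1OC(n2cnc3c(-c4ccco4)ncnc32)[C@H](O)[C@@H]1O` gives 2700 nM
compound 2 `Cc1csc(-c2ncnc3c2ncn3C2O[C@H](CO)[C@@H](O)[C@H]2O)c1` gives 5600 nM
compound 3 `Cn1cccc1-c1ncnc2c1ncn2C1O[C@H](CO)[C@@H](O)[C@H]1O` gives 15700 nM

Compound 3 has the highest number of the three, which makes it the weakest inhibitor measured so far. The change to compound 4 `OC[C@H]1OC(n2cnc3c(-c4cc[nH]n4)ncnc32)[C@H](O)[C@@H]1O` is 1H-pyrazol-3-yl in place of 1-methyl-1H-pyrrol-2-yl on an aromatic carbon on the shared core. Three measured steps exchange the group at this same place. They are a 5.8-fold higher number from compound 1 to compound 3 (0.76 log units; beyond the scatter) and a 2.8-fold higher number from compound 2 to compound 3 (0.45 log units; beyond the scatter) and also a 2.1-fold higher number from compound 1 to compound 2 (0.32 log units; beyond the scatter) among the other two. All are modest, though beyond the scatter. None of them involves 1H-pyrazol-3-yl, so they suggest only the likely size of the step and offer no direct test of the new group. Both other groups give lower numbers than compound 3 does, so a modest step towards a lower number is expected, with real uncertainty. The estimate means a 1.7-fold lower number from compound 3 to compound 4 (0.24 log units; within the scatter) in this assay as the expected change. Compound 4 is estimated at 9000 nM with an expected range from 2500 nM to 30000 nM for its measurement.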

Compound 4, half-maximal inhibitory concentration: 1170 nM
Compound 4: the middle estimate sits 7.7-fold (0.89 log units) above what was measured; measured number outside the range, below it.
By their numbers in this assay, from the lowest: compound 4; then compound 1; then compound 2; then compound 3.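

At this place on the shared core, 1H-pyrazol-3-yl gives the lowest number of the four in this assay, passing furan-2-yl (a 2.3-fold lower number from compound 1 to compound 4 (0.36 log units; beyond the scatter)) and 4-methylthiophen-2-yl (a 4.8-fold lower number from compound 2 to compound 4 (0.68 log units; beyond the scatter)). For the compounds shown here, the exchange for 1-methyl-1H-pyrrol-2-yl (a 13-fold lower number from compound 3 to compound 4 (1.13 log units; beyond the scatter)) is the only large step at this position, so the groups here span a wider range than the earlier compounds showed. Compared with 1-methyl-1H-pyrrol-2-yl, the entering group carries a hydrogen-bond donor and a second hetero atom and has one heavy atom fewer, and this single exchange does not separate these differences.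

The compounds shown leave open how 1-methyl-1H-pyrazol-3-yl or an amine at this place would compare. No measurement of any property of these groups accompanies the result.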